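Carbamate tail changes on a shared core

The compounds below may be only part of what the source reports. "The series", "measured", "known", "first", "only" and "open" are said of these compounds alone.

Measured so far:
- compound 1, `Cc1nc(S(C)(=O)=O)ccc1Oc1ncnc(OC2CCN(C(=O)O[C@H](C)CF)CC2)c1F`: 196 nM
- compound 2, `Cc1nc(S(C)(=O)=O)ccc1Oc1ncnc(OC2CCN(C(=O)O[C@@H](C)CF)CC2)c1F`: 186 nM
- compound 3, `Cc1nc(S(C)(=O)=O)ccc1Oc1ncnc(OC2CCN(C(=O)OC3(C(F)(F)F)CCC3)CC2)c1F`: 14.3 nM

In a functional assay on isolated protein for inhibition of Glucose-dependent insulinotropic receptor (Homo sapiens), read by HTRF and cAMP accumulation (on this read-out higher numbers stand for an effect only at larger amounts of compound and lower numbers for an effect already at smaller amounts), compound 1 gives 196 nM, the highest of the three numbers. Compound 2 gives 186 nM; the step of a 1.1-fold lower number from compound 1 to compound 2 (0.02 log units; within the scatter), and the two compounds differ only in configuration as drawn (the fact that compounds 1 and 2 differ only in the configuration as drawn). For the measured compounds named here, compound 3 gives 14.3 nM, and the step of a 14-fold lower number from compound 1 to compound 3 (1.14 log units; beyond the scatter) is the one large step in the set, so the group on the carbonyl carbon of the carbamate is the place where the numbers move.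

Compound 4, `Cc1nc(S(C)(=O)=O)ccc1Oc1ncnc(OC2CCN(C(=O)SC3CC3)CC2)c1F`, is not yet measured in this assay. It differs from compound 1 in a group of 4 heavy atoms (3 carbon, 1 sulfur; one three-membered non-aromatic ring of carbon only) in place of a group of 5 heavy atoms (3 carbon, 1 oxygen, 1 fluorine; no ring), on a carbonyl carbon. The step from compound 1 to compound 3 shows that a change at this carbonyl can lower the number far beyond the scatter, while the step from compound 1 to compound 2 shows that configuration at the chain carbon alone does not. Going by the values given here, neither step tracks a change of oxygen to sulfur nor of a chain to a three-membered ring, so no direct precedent exists, and a smaller move than that to compound 3 is anticipated, toward a lower number. Compound 4 is expected to give about 120 nM, in a range from 40 nM to 400 nM. That estimate means an expected step of a 1.6-fold lower number from compound 1 to compound 4 (0.21 log units; within the scatter).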

Compound 4, half-maximal effective concentration: 24.9 nM
For compound 4 the middle estimate is 4.8-fold (0.68 log units) above the measured one, and the stated range ends above it.
By their numbers in this assay, from the lowest: compounds 3 and 4 (each within the scatter of the next); then compounds 2 and 1 (each within the scatter of the next).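

a 7.9-fold lower number from compound 1 to compound 4 (0.90 log units; beyond the scatter) shows that a step beyond the scatter at this carbonyl carbon, whose other neighbour is the amide-type nitrogen in a ring, does not depend on the 1-(trifluoromethyl)cyclobutyl group: the group entering in compound 4 has fewer heavy atoms than the one it replaces, and its atoms are carbon and sulfur only. a 7.5-fold lower number from compound 2 to compound 4 (0.87 log units; beyond the scatter) reads the same way, and this pair adds little independent information beyond the first: the fact that compounds 1 and 2 differ only in the configuration as drawn With a 1.7-fold higher number from compound 3 to compound 4 (0.24 log units; within the scatter), the two very different groups on this carbonyl in compound 3 and compound 4 cannot be told apart on this read-out, so the 9-atom group in compound 3 offers no measurable gain over the 4-atom group in compound 4.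

Sulfur and the three-membered ring enter together in compound 4, so the shown compounds do not say which of the two carries the step. A cyclopropyl group on oxygen and an open isopropyl chain on sulfur would each separate these two changes, and a carbonyl bearing a simple amine would test whether this position tolerates a link through nitrogen.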